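The source may hold more compounds than are shown below. What is called first, only, known or untested is meant among the compounds shown, and "the series" means these compounds.

In a functional assay on HepG2 cells (Homo sapiens) for inhibition, read by MTT assay, with a stated time of 24 h (a higher number here means a weaker inhibitor, a lower number a stronger inhibitor), compound 1 `CC1(C)[C@H]2CC[C@]1(C)N(Cc1cn(-c3ccccc3Br)nn1)C(=O)C2` gives 150 nM and compound 2 `CC1(C)[C@H]2CC[C@]1(C)N(Cc1cn(-c3ccc(Br)cc3)nn1)C(=O)C2` gives 110 nM. Going by the values given here, the only measured step is a 1.4-fold lower number from compound 1 to compound 2 (0.13 log units; within the scatter), so compound 2 stands level with compound 1 within the scatter, and the two cannot be ranked.

Compound 3 `CC1(C)[C@H]2CC[C@]1(C)N(Cc1cn(-c3ccc(Cl)cc3)nn1)C(=O)C2` shares the core of compound 2 and differs from it at one place, with chloro in place of bromo on an aromatic carbon. Among the compounds with values here, no measured pair exchanges one halogen for another, so the evidence is indirect. Within the data shown here, the one guide is a 1.4-fold lower number from compound 1 to compound 2 (0.13 log units; within the scatter), a change of 2-bromophenyl to 4-bromophenyl that stayed within the scatter. On that basis, no step beyond the scatter is expected in this assay, in either direction. The expected step is a 1.1-fold higher number from compound 2 to compound 3 (0.04 log units; within the scatter). Compound 3 is estimated at 120 nM, with an expected range of 55 nM to 260 nM.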

Compound 3, half-maximal inhibitory concentration: 90 nM
Compound 3: the middle estimate sits 1.3-fold (0.12 log units) above what was measured; measured number inside the range.
By their numbers in this assay, from the lowest: compounds 3, 2 and 1 (each within the scatter of the next).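

In this assay, the exchange of halogen on an aromatic carbon, para to a large group, can now be read directly: a 1.2-fold lower number from compound 2 to compound 3 (0.09 log units; within the scatter) shows that bromo and chloro at this place cannot be told apart. Changing both the halogen and its place on the ring leaves the picture unchanged, since a 1.7-fold lower number from compound 1 to compound 3 (0.22 log units; within the scatter) also stays within the scatter, so compounds 1, 2 and 3 stand level and cannot be ranked. No measurement at hand bears on why these halogen changes leave the number so little moved.

The compounds shown carry only bromo and chloro on this ring, so it remains open whether fluoro, a methoxy group, an amine or a carboxylic acid at this place would stay level with them. From the compounds shown here alone, whether 2-chlorophenyl would also stay level remains open too.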